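A few compounds are considered here, and "the series" means these few. Any claim that something is new, unique, unknown or untested is made for them only; others in the source may bear on it.

Compound 3, `COc1ccccc1-c1sc(N)c(C(=O)c2ccc(Cl)cc2)c1CC(C)(C)C`, gives 1% in an assay on CHO cells for displacement of a labelled ligand from adenosine receptor A3 (Homo sapiens), read by scintillation counting, tested at 10 uM; on this read-out lower numbers stand for less inhibition and higher numbers for more inhibition at the one concentration tested (going by the name of the read-out). On this read-out compound 3 stands level with compound 1, `CC(C)(C)Cc1c(-c2ccccn2)sc(N)c1C(=O)c1ccc(Cl)cc1`, which gives 1% in this assay, so the two share the lowest of the three numbers. The remaining member of the set, compound 2, `CC(C)(C)Cc1c(-c2ccc(F)cc2)sc(N)c1C(=O)c1ccc(Cl)cc1`, gives 9% in this assay. None of the three measured steps reaches beyond the scatter: no change at the digits printed from compound 1 to compound 3 (within the scatter), a number 8 percentage points lower from compound 2 to compound 3 (within the scatter) and a number 8 percentage points higher from compound 1 to compound 2 (within the scatter). Thus three different aryl groups on the same aromatic carbon of the shared core have all left this assay close to its floor.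

Compound 4, `CC(C)c1ccc(-c2sc(N)c(C(=O)c3ccc(Cl)cc3)c2CC(C)(C)C)cc1`, is the next variation at that position: 4-isopropylphenyl in place of 2-methoxyphenyl on an aromatic carbon. For the measured compounds named here, no measured step introduces an alkyl-bearing phenyl group, so there is no direct precedent, but the steps that bear on it are the three exchanges of aryl group just described, each within the scatter. A step of no more than the scatter is therefore expected, in no particular direction, and compound 4 is estimated at 4% with a range of -5% to 15%, a step of a number 3 percentage points higher from compound 3 to compound 4 (within the scatter) that is expected to stay within the usual spread.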

Compound 4, a percentage reported as inhibition, at one concentration (the size of the read-out at that concentration, not a potency): 1%
Compound 4: middle estimate off by 3 percentage points, on the high side; the measured number falls inside the stated range.
By their numbers in this assay, from the lowest: compounds 1, 3, 4 and 2 (each within the scatter of the next).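

In this assay the exchange of 2-methoxyphenyl for 4-isopropylphenyl on the aromatic carbon next to the ring sulfur reads as no change at the digits printed from compound 3 to compound 4 (within the scatter) and the other two comparisons at this carbon read as no change at the digits printed from compound 1 to compound 4 (within the scatter) and a number 8 percentage points lower from compound 2 to compound 4 (within the scatter) without any of them leaving the scatter. The new group has more heavy atoms than the 2-methoxyphenyl it replaces and no hydrogen-bond acceptor, so the four compounds now span aryl groups with and without an acceptor, and with an isopropyl or a fluoro at the same place on the phenyl ring, and none of these differences separates in this read-out. No measurement on hand offers an explanation for this flat result, and the numbers alone cannot supply one.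

What the compounds shown leave open is whether anything other than an aryl group at this carbon, such as a morpholine, a carboxylic acid or a longer alkyl chain, would lift the number clear of the scatter. They also leave open whether a change elsewhere on the shared core, for instance a smaller chain in place of the neopentyl group or a free amide in place of the amino group, would do so.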